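Replacing a Ring by a Short Chain at the Aromatic Nitrogen

The source may report more compounds than this note shows. Statements on the series, on what has been measured and on what is new or still open speak of the compounds shown alone.

Compound 1, `COc1cc(Cc2nc3c(N)nc(F)nc3n2CC2CCCO2)cc(OC)c1OC`, gives 22900 nM in a functional assay on MCF7 cells (Homo sapiens) for antiproliferative activity; a higher number here means a weaker inhibitor, a lower number a stronger inhibitor.
Compound 2, `COc1cc(Cc2nc3c(N)ncnc3n2CC2CCCCC2)cc(OC)c1OC`, gives 39800 nM in this assay.
Compound 3, `C#CCCCn1c(Cc2cc(OC)c(OC)c(OC)c2)nc2c(N)ncnc21`, gives 24000 nM in this assay.

Compound 1 shows the lowest of the three numbers, but its gaps to compound 2 and to compound 3 both stay within the usual scatter, so none of the three can be set apart from the others.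

Compound 4, `CCCn1c(Cc2cc(OC)c(OC)c(OC)c2)nc2c(N)nc(F)nc21`, arises from compound 1 by ethyl in place of oxolan-2-yl on a saturated chain carbon bound to an aromatic nitrogen; read one bond further out, (oxolan-2-yl)methyl becomes propyl. Within the data shown here, only one measured step touches the same place: a 1.7-fold lower number from compound 2 to compound 3 (0.22 log units; within the scatter), where one saturated group on that chain carbon was swapped for another without a change beyond the scatter. Compound 2 and compound 3 differ from compound 1 in more than one place, so this is only a rough guide. Compound 4 is therefore expected to stay close to compound 1, with a step of a 1.1-fold higher number from compound 1 to compound 4 (0.04 log units; within the scatter), and its estimated value is 25000 nM, ranging from 10000 nM to 60000 nM.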

Compound 4, half-maximal inhibitory concentration: 25100 nM
Compound 4: the middle estimate sits 1.0-fold (0.00 log units) below what was measured; the range from low to high includes it.
By their numbers in this assay, from the lowest: compounds 1, 3, 4 and 2 (each within the scatter of the next).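

In this assay, the step from the ring-bearing group to the open chain is a 1.1-fold higher number from compound 1 to compound 4 (0.04 log units; within the scatter), and it stays within the scatter. The earlier step at this place swapped one group for another of no hydrogen-bond acceptor, whereas this one removes the five-membered ring and its oxygen, the group's only hydrogen-bond acceptor, and cuts the group from 5 heavy atoms to 2, all on the core of compound 1. So, for this pair, neither the ring nor that oxygen is needed to keep the number where it stands, and no measurement at hand offers an explanation for this.

From the compounds shown here alone, both steps at this place stay within the scatter, so it remains open whether any group here can move the number clearly. An amine, a carboxylic acid or a much longer chain such as octyl in this place would test that.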